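The source may hold more compounds than are shown below. What is called first, only, known or untested is meant among the compounds shown, and "the series" means these compounds.

In an ADME assay on HepG2 cells (Homo sapiens) for cytotoxicity, read by CellTiter-Glo, with a stated time of 48 h (a lower number here means that less compound is tolerated, a higher number that more compound is tolerated), compound 1 `CS(=O)(=O)c1ccc(-c2nc3ccc(Cl)cc3nc2-c2ccc(Cl)cc2)cc1` gives 2000 nM, and compound 2 `CS(=O)(=O)c1ccc(-c2nc3ccc(Br)cc3nc2-c2ccc(Cl)cc2)cc1` gives 2000 nM. The step of no change at the digits printed from compound 2 to compound 1 (within the scatter) goes with the change (chloro in place of bromo on an aromatic carbon). Compound 3 `CCCCNc1nc2cc(Br)ccc2nc1S(C)(=O)=O` gives 7940 nM in this assay, the highest of the three numbers; the difference between its core and the core of compound 2 is not broken down here. Compound 4 `CCCCNc1nc2cc(Cl)ccc2nc1S(C)(=O)=O` has not yet been measured. For the measured compounds named here, it differs from compound 3 by chloro in place of bromo on an aromatic carbon, the same change as the one made from compound 2 to compound 1. Because no change at the digits printed from compound 2 to compound 1 (within the scatter) stayed within the scatter, a step of about the same small size is expected here. For compound 4 the expected step is a 1.0-fold higher number from compound 3 to compound 4 (0.00 log units; within the scatter). Compound 4 is therefore estimated to give 8000 nM in this assay, most likely between 4000 nM and 16000 nM.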

Compound 4, half-maximal cytotoxic concentration: 6310 nM
Compound 4: middle estimate off by 1.3-fold (0.10 log units), on the high side; low and high end bracket the measured number.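

In this assay, chloro in place of bromo on an aromatic carbon gives a 1.3-fold lower number from compound 3 to compound 4 (0.10 log units; within the scatter). This change therefore carries from one core to the other with no difference beyond the scatter: the same change on two cores in this assay, no change at the digits printed (within the scatter) from compound 2 to compound 1 and a 1.3-fold lower number (0.10 log units; within the scatter) from compound 3 to compound 4, 1.3-fold (0.10 log units) apart, within the scatter of two such steps It does not show that the swap would stay this small on any further core, and it rests on just two pairs, each with a step too small to separate chloro from bromo.

The compounds shown leave open whether fluoro or methoxy in place of the halogen, or a longer chain on the amino nitrogen of compound 4, would move the number beyond the scatter. They also leave open which part of the two cores goes with the gap between their numbers.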